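A few compounds are considered here, and "the series" means these few. Any claim that something is new, unique, unknown or untested is made for them only; others in the source may bear on it.

Values in a functional assay on HeLa cells (Homo sapiens) for cytotoxicity, read by WST assay, with a stated time of 48 h; a lower number here means a stronger inhibitor, a higher number a weaker inhibitor:
- compound 1 `O[C@@H](c1ccccc1)[C@H]1CO[C@H](c2ccccc2)[C@@H](C/C=C/c2ccccn2)C1`: 33800 nM
- compound 2 `COc1cccc(/C=C/C[C@H]2C[C@@H]([C@@H](O)c3ccccc3)CO[C@@H]2c2ccccc2)c1`: 10900 nM
- compound 3 `O=[N+]([O-])c1cccc(/C=C/C[C@H]2C[C@@H]([C@@H](O)c3ccccc3)CO[C@@H]2c2ccccc2)c1`: 7850 nM

Compound 3 stands at the low end of these numbers, a position it shares with compound 2 within the scatter: a 1.4-fold lower number from compound 2 to compound 3 (0.14 log units; within the scatter). Its separation from the pyridin-2-yl member is clearer: a 4.3-fold lower number from compound 1 to compound 3 (0.63 log units; beyond the scatter).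

Compound 4 `O[C@@H](c1ccccc1)[C@H]1CO[C@H](c2ccccc2)[C@@H](C/C=C/C2CCCC2)C1` changes the same end group: cyclopentyl in place of 3-nitrophenyl on a double-bonded chain carbon bound to a double-bonded chain carbon. The aromatic ring gives way to a non-aromatic ring of carbon only. The measured steps at this place are modest, a 3.1-fold lower number from compound 1 to compound 2 (0.49 log units; beyond the scatter) and a 4.3-fold lower number from compound 1 to compound 3 (0.63 log units; beyond the scatter), while the change on the aromatic ring, a 1.4-fold lower number from compound 2 to compound 3 (0.14 log units; within the scatter), stays within the scatter. None of them tests a non-aromatic ring, so the evidence is indirect. Compound 1, at 33800 nM, marks the upper end of the measured range, and a modest move toward higher numbers is expected. The expected step is a 1.8-fold higher number from compound 3 to compound 4 (0.25 log units; within the scatter). For compound 4 the estimated value is 14000 nM, with an expected range of 5500 nM to 38000 nM.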

Compound 4, half-maximal inhibitory concentration: 9330 nM
Compound 4: middle estimate off by 1.5-fold (0.18 log units), on the high side, within the range that was stated.
By their numbers in this assay, from the lowest: compounds 3, 4 and 2 (each within the scatter of the next); then compound 1.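

In this assay, an aromatic ring is not needed at this end of the chain: cyclopentyl, a non-aromatic ring of carbon only, reads level with 3-nitrophenyl (a 1.2-fold higher number from compound 3 to compound 4 (0.08 log units; within the scatter)) and with 3-methoxyphenyl (a 1.2-fold lower number from compound 2 to compound 4 (0.07 log units; within the scatter)). The pyridin-2-yl member is now the only one of the four set apart, since the change to cyclopentyl also gives a clear step (a 3.6-fold lower number from compound 1 to compound 4 (0.56 log units; beyond the scatter)), while compounds 2, 3 and 4 lie within the scatter of one another. No measurement shown here explains this.

An unsubstituted phenyl or a pyridin-3-yl group at this place would show whether the ring nitrogen goes with the higher number of compound 1. An open butyl chain, an amine or a carboxylic acid on the same double-bonded chain carbon would test how far the end group can vary.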